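The source may report more compounds than this note shows. Statements on the series, on what has been measured and on what is new or still open speak of the compounds shown alone.

Measured compounds:
Compound 1 `COc1ccc(Cl)cc1S(=O)(=O)Nc1ccc(-c2nc3ccccc3o2)cc1` gives 75000 nM in an ADME assay on HEK293 cells (Homo sapiens) for cytotoxicity, read by resazurin assay, with a stated time of 48 h; a lower number here means that less compound is tolerated, a higher number that more compound is tolerated.
Compound 2 `O=S(=O)(Nc1ccc(-c2nc3ccccc3o2)cc1)c1ccc(C(F)(F)F)cc1` gives 94000 nM in this assay.
Compound 3 `COc1ccc(S(=O)(=O)Nc2ccc3oc(-c4ccccc4)nc3c2)cc1` gives 91000 nM in this assay.

The three measured compounds share a core, and in this assay their numbers sit close together. Compound 1 stands at one end of the three numbers, but its gap to compound 3 and its gap to compound 2 are both within the usual scatter, so nothing separates them with confidence. For the measured compounds named here, no step between two measured compounds differing in a single place is available here.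

Compound 4 `CS(=O)(=O)Nc1ccc(-c2nc3ccccc3o2)cc1` is not yet measured. Its structure differs from compound 1 as follows: methyl in place of 5-chloro-2-methoxyphenyl on a sulfonyl sulfur. Because the three measured compounds, with their different groups on the sulfonyl sulfur, cluster as they do, the account expects the step of a 1.3-fold higher number from compound 1 to compound 4 (0.12 log units; within the scatter) from compound 1 to compound 4 to be small and within the scatter, with a slight lean towards more compound being tolerated. Compound 4 is therefore estimated at 100000 nM in this assay, in a range from 50000 nM to 200000 nM.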

Compound 4, half-maximal cytotoxic concentration: > 100000 nM
Compound 4: only a limit was reported (the forecaster's own chance of this, stated with the estimate: 30%); the middle value lies on the limit itself.
By their numbers in this assay, from the lowest: compounds 1, 3 and 2 (each within the scatter of the next). At a limit, above all of these: compound 4.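

Compound 4 gives > 100000 nM in this assay, and that value is a limit of the assay. On a sulfonyl sulfur whose other neighbour is the sulfonamide nitrogen, methyl in place of 5-chloro-2-methoxyphenyl takes away the aromatic ring altogether, and the change reads as an at least 1.3-fold higher number from compound 1 to compound 4 (0.12 log units; that floor lies within the scatter). The earlier compounds all carry an aromatic ring at this place, whereas compound 4 shows that the number does not fall when that ring is gone, though the size of the step stays unknown: the limit of > 100000 nM in this assay, at which 1 of the 4 values shown sits.

The compounds shown leave open what an amine, a carboxylic acid or a longer chain on the sulfonyl sulfur would do to the number. They also leave open whether any group at this place can bring the number down beyond the scatter.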